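The source may report more compounds than this note shows. Statements on the series, on what has been measured and on what is new or still open speak of the compounds shown alone.

Compound 1 `O=c1cc(CSC(=S)N2CCCC2)oc2ccccc12`: 9100 nM
Compound 2 `O=c1c(Cl)c(CSC(=S)N2CCOCC2)oc2ccccc12`: 9000 nM

Of the compounds shown here, two have been measured in a functional assay on HEp-2 cells (Homo sapiens) for antiproliferative activity, read by MTT assay, with a stated time of 72 h; on this read-out lower numbers stand for stronger inhibition and higher numbers for weaker inhibition. Compound 1 gives 9100 nM and compound 2 gives 9000 nM. Compound 2 has the lowest of the two numbers, but its nearest neighbour, compound 1, lies within the scatter of it, so the two values cannot be told apart.

Compound 3 `O=c1cc(CSC(=S)N2CCOCC2)oc2ccccc12` has not been measured. It differs from compound 2 in one place: hydrogen in place of chloro on an aromatic carbon. For the measured compounds named here, no measured pair shows this change on its own, so the size and direction of its effect are unknown from the data at hand. The two measured values both sit close together, and nothing in them points to a large shift for compound 3 in either direction. The step from compound 2 to compound 3 is therefore expected to be a 1.1-fold higher number from compound 2 to compound 3 (0.05 log units; within the scatter), that is, no change beyond the scatter. On that basis compound 3 is estimated to give 10000 nM in this assay, with a plausible range from 4000 nM to 25000 nM.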

Compound 3, half-maximal inhibitory concentration: > 25000 nM
Compound 3: a limit, no number; the forecaster's own chance of this, stated with the estimate: 10%; middle value at least 2.5-fold (0.39 log units) from the limit.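

In this assay compound 3 stands only as a limit and not as a number: the limit of > 25000 nM in this assay, at which 1 of the 3 values shown sits.

Hydrogen in place of chloro on the aromatic carbon two atoms from the ring oxygen gives an at least 2.7-fold higher number from compound 2 to compound 3 (0.44 log units; beyond the scatter), which is the first reading of this position on its own and shows that, with morpholin-4-yl on the thiocarbonyl carbon, the chloro group goes with a measurable number while hydrogen does not reach one. Morpholin-4-yl in place of pyrrolidin-1-yl on the thiocarbonyl carbon gives an at least 2.7-fold higher number from compound 1 to compound 3 (0.43 log units; beyond the scatter), so with hydrogen on the aromatic carbon this second place counts as well, and the matching numbers of compound 1 and compound 2 conceal two changes that each matter when read singly.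

From the compounds shown here alone, both steps end at a limit, so their full size stays unknown, and the chloro group has been read only with morpholin-4-yl, leaving open what it would do with pyrrolidin-1-yl on the thiocarbonyl carbon. Nor do the compounds shown say whether the effect belongs to chloro alone or would also appear with bromo, fluoro or methyl on the same aromatic carbon.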